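Swapping Ethyl for Methoxy on a Shared Core

The source may report more compounds than this note shows. Statements on the series, on what has been measured and on what is new or still open speak of the compounds shown alone.

Compound 1 `O=C(c1ccc(F)cc1)c1ccn(-c2ccc3c(c2)B(O)OC3)c1` gives > 10 ug/mL in an ADME assay on L929 cells (Mus musculus) for cytotoxicity, read by resazurin assay, with a stated time of 72 h (a higher number here means a weaker inhibitor, a lower number a stronger inhibitor), a limit of the assay rather than a number.
Compound 2 `CCc1ccc(C(=O)c2ccn(-c3ccc4c(c3)B(O)OC4)c2)cc1` gives > 10 ug/mL in this assay, again a limit.

For the measured compounds named here, both values sit at the limit of > 10 ug/mL in this assay, at which 2 of the 2 values shown sit, so compound 2 stands at the limit, and the single measured step, a step that the two limits leave unreadable from compound 1 to compound 2, cannot be read in size or direction. Compound 3 `COc1ccc(C(=O)c2ccn(-c3ccc4c(c3)B(O)OC4)c2)cc1` differs from compound 2 by methoxy in place of ethyl on an aromatic carbon. Going by the values given here, the only measured step concerns the same position, but its unreadable size gives no basis to expect a shift beyond the scatter in this assay. Compound 3 is therefore expected to give 15 ug/mL, within 8 ug/mL to 40 ug/mL. This estimate means an expected step that the limit leaves unreadable from compound 2 to compound 3.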

Compound 3, half-maximal inhibitory concentration: > 10 ug/mL
Compound 3 was reported as a limit; the forecaster's own chance of this, stated with the estimate: 85%; the middle value does not contradict the limit.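

For the compounds shown here, compound 3 also gives only a limit, so no step among compound 1, compound 2 and compound 3 can be read in this assay: the limit of > 10 ug/mL in this assay, at which 3 of the 3 values shown sit. Where each compound's true value lies, and whether fluoro, ethyl or methoxy shifts it, stays open.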